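Hydrazide series: methoxy added to the fused ring of compound 2

This account rests on a few compounds, and the source may have more. Where it says the series, first, only, none or still open, it means among the compounds named here.

Measured so far:
- compound 1 `CCCNNC(=O)c1ccc(CNC(=O)c2ccc3ccccc3n2)cc1`, in an assay on isolated protein for inhibition of protein deacetylase HDAC6 (Homo sapiens), read by fluorescence, with a stated time of 2 h (on this read-out lower numbers stand for stronger inhibition and higher numbers for weaker inhibition), compound 1 gives > 10000 nM
- compound 2 `CCCNNC(=O)c1ccc(CNC(=O)c2cc3ccccc3o2)cc1`, in this assay compound 2 gives > 10000 nM

The value for compound 1 is a limit of the assay, not a number. The value for compound 2 is likewise a limit, not a number. Within the data shown here, both values shown sit at the limit of > 10000 nM in this assay, at which 2 of the 2 values shown sit, so compound 2 cannot be placed relative to compound 1, and no step between measured compounds can be stated.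

Compound 3 `CCCNNC(=O)c1ccc(CNC(=O)c2cc3cc(OC)ccc3o2)cc1` differs from compound 2 by methoxy in place of hydrogen on an aromatic carbon. With nothing measured for this kind of change, the expected step is a step that the limit leaves unreadable from compound 2 to compound 3, that is, none beyond the scatter. Compound 3 is therefore estimated at 20000 nM, in the range 8000 nM to 60000 nM, and is expected most likely to return only a limit again.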

Compound 3, half-maximal inhibitory concentration: > 10000 nM
Compound 3: only a limit was reported; the forecaster's own chance of this, stated with the estimate: 85%; the middle value lies beyond the limit too.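

Among these compounds, no step from compound 2 to compound 3 can be read in this assay, since both values are limits of the assay: the limit of > 10000 nM in this assay, at which 3 of the 3 values shown sit. The compounds shown leave open whether methoxy in place of hydrogen on an aromatic carbon changes inhibition at all, and how compounds 1, 2 and 3 rank.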